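Compound 4: what the step from compound 3 suggests

The source may hold more compounds than are shown below. What is called first, only, known or untested is meant among the compounds shown, and "the series" means these compounds.

compound 1 `O=c1cc(Cn2cc(CCCCl)nn2)c2ccc(O)cc2o1` — in a functional assay on CFPAC-1 cells (Homo sapiens) for inhibition, read by MTT assay, with a stated time of 72 h (a higher number here means a weaker inhibitor, a lower number a stronger inhibitor), compound 1 gives 75800 nM
compound 2 `CCCCCCc1cn(Cc2cc(=O)oc3cc(O)ccc23)nn1` — in this assay compound 2 gives > 100000 nM, a limit of the assay
compound 3 `O=c1cc(Cn2cc(CCc3ccccc3)nn2)c2ccc(O)cc2o1` — in this assay compound 3 gives > 100000 nM, a limit of the assay

Compound 3 stands at the ceiling of this assay: its value is a limit, not a measured number, and compound 2 sits at the same limit (the limit of > 100000 nM in this assay, at which 2 of the 3 values shown sit). Only compound 1 yields a number. The step of an at least 1.3-fold higher number from compound 1 to compound 3 (0.12 log units; that floor lies within the scatter) rests on a floor that lies within the scatter, and the step that the two limits leave unreadable from compound 2 to compound 3 cannot be read at all, so the chain changes measured so far give no readable size.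

Compound 4 `O=c1cc(Cn2cc(CSC(=S)N3CCNCC3)nn2)c2ccc(O)cc2o1` carries a group of 9 heavy atoms (5 carbon, 2 nitrogen, 2 sulfur; one six-membered non-aromatic ring with 2 hetero atoms) in place of a group of 7 heavy atoms (7 carbon; one six-membered aromatic ring of carbon only), on a saturated chain carbon bound to an aromatic carbon. For the measured compounds named here, no measured step covers a change of this kind. The steps of an at least 1.3-fold higher number from compound 1 to compound 2 (0.12 log units; that floor lies within the scatter), an at least 1.3-fold higher number from compound 1 to compound 3 (0.12 log units; that floor lies within the scatter) and a step that the two limits leave unreadable from compound 2 to compound 3 each swapped one chain end for another carbon chain or a phenyl, and every value lay at or near the limit. The step from compound 3 to compound 4 is therefore expected to stay in that region, with a wide band for the unfamiliar group, and is estimated as an at least 1.4-fold lower number from compound 3 to compound 4 (0.15 log units; that floor lies within the scatter). Compound 4 is expected to give 70000 nM in this assay, between 15000 nM and 300000 nM.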

Compound 4, half-maximal inhibitory concentration: > 100000 nM
Compound 4: only a limit was reported; the forecaster's own chance of this, stated with the estimate: 45%; middle value at least 1.4-fold (0.15 log units) away from the limit.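

In this assay compound 4 gives > 100000 nM, which is a limit of the assay, so this position on a saturated chain carbon bound to an aromatic carbon now shows no readable number with a group quite unlike the carbon chains and benzyl seen earlier, one with a six-membered non-aromatic ring, sulfur atoms and a hydrogen-bond donor. Against the one compound with a measured number, the result is an at least 1.3-fold higher number from compound 1 to compound 4 (0.12 log units; that floor lies within the scatter), so compound 4 cannot be set apart from compound 1. The steps to compound 4 from compound 2 and compound 3 cannot be read, because both ends of each step sit at the same limit: the limit of > 100000 nM in this assay, at which 3 of the 4 values shown sit.

The compounds shown leave open whether any group at this position gives a number clearly stronger than that of compound 1 in this assay, for example a primary amine, a carboxylic acid or a short chain ending in a hydroxyl. They also leave open how far apart compound 2, compound 3 and compound 4 really lie, as none of the three has a measured number.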